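Exchanging an aryl ether for an anilino group

A few compounds are considered here, and "the series" means these few. Any claim that something is new, unique, unknown or untested is made for them only; others in the source may bear on it.

For the measured compounds named here, compound 1 `Cc1cc(-c2cnn3c(NCC4CCOCC4)nc(Oc4cccc(F)c4F)nc23)ccc1C(=O)NC1CC1` is the only compound with a number here: in an ADME assay on the whole organism for pharmacokinetics, with Mus musculus as the target, at a dose of 10 mg/kg by the oral route (a lower number here means less compound in the circulation, a higher number more compound in the circulation at the dose given), compound 1 gives 4000 ng.h/mL. Compound 2 `Cc1cc(-c2cnn3c(NCC4CCOCC4)nc(Nc4cccc(F)c4)nc23)ccc1C(=O)NC1CC1` has in this assay "not determined" (no result reported). Compound 3 `Cc1cc(-c2cnn3c(NCC4CCOCC4)nc(Nc4ccccc4F)nc23)ccc1C(=O)NC1CC1` differs from compound 1 by one change: (2-fluorophenyl)amino in place of 2,3-difluorophenoxy on an aromatic carbon. Going by the values given here, no measured pair shows what such a swap does to exposure, so the expectation leans on compound 1 alone. The step of a 1.3-fold lower number from compound 1 to compound 3 (0.12 log units; within the scatter) is expected to be small, in either direction or none beyond the scatter. Compound 3 is therefore estimated at 3000 ng.h/mL, with a range from 800 ng.h/mL to 10000 ng.h/mL.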

Compound 3, area under the concentration-time curve: 1900 ng.h/mL
Compound 3: middle estimate off by 1.6-fold (0.20 log units), on the high side; the range from low to high includes it.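

In this assay there is a 2.1-fold lower number from compound 1 to compound 3 (0.32 log units; beyond the scatter) when (2-fluorophenyl)amino replaces 2,3-difluorophenoxy on this aromatic carbon between two ring nitrogen atoms. So this position is sensitive to the swap, although two things change at once: the oxygen link becomes a nitrogen link carrying a hydrogen-bond donor, and the ring has one fluorine fewer. Nothing measured here explains the drop. Which of these two changes matters remains open, as does how a morpholine or another non-aromatic amine would behave at this carbon.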